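Amide to Ester on a Shared Core

The compounds below may be only part of what the source reports. "The series", "measured", "known", "first", "only" and "open" are said of these compounds alone.

Compound 2 `Cc1nccn1-c1ccc(COc2cc(F)cc(C3(C(=O)N(C)C)CCOCC3)c2)cc1` gives the highest of the two numbers measured in an assay on blood for inhibition of Polyunsaturated fatty acid 5-lipoxygenase (Homo sapiens) (a higher number here means a weaker inhibitor, a lower number a stronger inhibitor), namely 810 nM. Its nearest neighbour is compound 1 `Cc1nccn1-c1ccc(COc2cc(F)cc(C3(C(N)=O)CCOCC3)c2)cc1`, which in this assay gives 340 nM. Within the data shown here, the only measured step, a 2.4-fold higher number from compound 1 to compound 2 (0.38 log units; beyond the scatter), put dimethylamino in place of amino on the carbonyl carbon. Compound 3 `CCOC(=O)C1(c2cc(F)cc(OCc3ccc(-n4ccnc4C)cc3)c2)CCOCC1` changes the same place again: ethoxy in place of dimethylamino on a carbonyl carbon. Among the measured compounds shown here, no measured step tests an ethoxycarbonyl group, and the modest loss in a 2.4-fold higher number from compound 1 to compound 2 (0.38 log units; beyond the scatter) is the only guide. Compound 3 is therefore expected to shift little or slightly upward, an estimated 1.5-fold higher number from compound 2 to compound 3 (0.17 log units; within the scatter). The estimated value of compound 3 in this assay is 1200 nM, with a range from 400 nM to 3600 nM.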

Compound 3, half-maximal inhibitory concentration: 200 nM
Compound 3: middle estimate off by 6.0-fold (0.78 log units), on the high side; measured number below the stated range.
By their numbers in this assay, from the lowest: compounds 3 and 1 (each within the scatter of the next); then compound 2.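

In this assay, ethoxy in place of dimethylamino on the carbonyl carbon gives a 4.1-fold lower number from compound 2 to compound 3 (0.61 log units; beyond the scatter) and so reverses the loss seen with dimethylamino, although both groups count the same number of heavy atoms. Ethoxy in place of amino gives a 1.7-fold lower number from compound 1 to compound 3 (0.23 log units; within the scatter) and leaves compound 3 and compound 1 level within the scatter. Nothing at hand explains the difference between these groups. As far as these compounds go, it remains open whether a methoxy group, a longer alkoxy chain or a carboxylic acid at this carbonyl carbon would hold this level.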